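From 4-methoxyphenyl to furan-3-yl: an open cytotoxicity question

The compounds below may be only part of what the source reports. "The series", "measured", "known", "first", "only" and "open" are said of these compounds alone.

Measured in an ADME assay on Vero cells (Chlorocebus sabaeus) for cytotoxicity, read by MTT assay, with a stated time of 96 h; a higher number here means that more compound is tolerated, a lower number that less compound is tolerated:
- compound 1 `C/C(=N\NC(N)=O)c1ccc2[nH]c(-c3ccc(Cl)cc3)nc2c1`: > 100000 nM
- compound 2 `COc1ccc(-c2nc3cc(/C(C)=N/NC(N)=O)ccc3[nH]2)cc1`: "not determined" (no result reported)
- compound 3 `COc1ccc(-c2nc3cc(/C(C)=N/NC(N)=O)ccc3[nH]2)c(OC)c1`: 80000 nM

Compound 2 has no place on the numbers, since its entry reads "not determined" (no result reported). The comparison therefore has no starting value. Among the measured compounds shown here, only two other compounds offer any guidance. For compound 1, the entry > 100000 nM is a limit of this assay and not a number. Compound 3 gives a true number, 80000 nM.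

The compound still to be measured is compound 4 `C/C(=N\NC(N)=O)c1ccc2[nH]c(-c3ccoc3)nc2c1`. It shares the core of compound 2 and differs in one group, with furan-3-yl in place of 4-methoxyphenyl on an aromatic carbon. For the measured compounds named here, no pair of measured compounds here differs in just one place, so the data give no direct size for such a change.

With nothing to suggest a direction, the expectation is for no step beyond the usual scatter, with compound 4 landing in the same region as compound 3 at 80000 nM. It could also reach the limit of this assay and return no exact number. Compound 4 is expected at about 85000 nM, with an estimated range from 40000 nM to 150000 nM.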

Compound 4, half-maximal cytotoxic concentration: > 100000 nM
Compound 4: no number, only a limit; the forecaster's own chance of this, stated with the estimate: 50%; middle value at least 1.1-fold (0.07 log units) from the limit.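

In this assay compound 4 gives > 100000 nM, which is a limit and not a number. Compound 1 ends at the same limit, so no step between compound 1 and compound 4 can be read: the limit of > 100000 nM in this assay, at which 2 of the 4 values shown sit.

The compounds shown leave open whether furan-3-yl in place of 4-methoxyphenyl changes how much compound is tolerated.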